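The compounds below may be only part of what the source reports. "The series", "measured", "known", "first", "only" and "open" are said of these compounds alone.

The measurements come from a functional assay on U-87MG ATCC cells for inhibition, with U-87 MG (Homo sapiens) as the target, read by MTT assay, with a stated time of 72 h; on this read-out higher numbers stand for weaker inhibition and lower numbers for stronger inhibition. Compound 1 `Cc1ccnc(NC(c2ccccc2C)c2ccc3cccnc3c2O)c1` gives in this assay only a limit, > 10000 nM, and not a number. On the values shown, compound 1 therefore stands at the weak end of what can be seen, sitting at the limit of > 10000 nM in this assay, at which 1 of the 2 values shown sits. For the measured compounds named here, the one other measured compound, compound 2 `Oc1c(C(c2ccc(C(F)(F)F)cc2)N2CCCCC2)ccc2ccoc12`, carries a different core; in this assay compound 2 gives 5000 nM. Going by the values given here, no step between compound 1 and compound 2 is counted, and the two values show only that compound 2 returned a number where compound 1 did not.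

Compound 3 `Cc1ccnc(NC(c2ccccc2F)c2ccc3cccnc3c2O)c1` keeps the core of compound 1 and differs from it by fluoro in place of methyl on an aromatic carbon. No measured pair among the shown compounds carries this kind of change, so there is nothing to set its size against. The step is expected to be small, with no direction beyond the scatter, and a number no higher from compound 1 to compound 3 (the limit leaves the size open) is the estimated step, resting on compound 1 already sitting at the limit of > 10000 nM in this assay, at which 1 of the 2 values shown sits. Compound 3 is estimated in this assay at 10000 nM, with a range from 3000 nM to 30000 nM.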

Compound 3, half-maximal inhibitory concentration: 13100 nM
Estimate against measurement, compound 3: 1.3-fold (0.12 log units) below, and the stated range covers the measured number.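

For the compounds shown here, no step from compound 1 to compound 3 can be read, so the swap of 2-methylphenyl to 2-fluorophenyl has no size here. In this assay compound 1 gives only a limit (> 10000 nM) and not a number. The compounds shown leave open how far, and in which direction, this change moves the read-out on the shared core.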